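Chain length at the amine and maximal response

The compounds below may be only part of what the source reports. "The series", "measured", "known", "first", "only" and "open" are said of these compounds alone.

Measured compounds:
compound 1 `COc1ccccc1-c1cc(CN(C)C)ccc1Cl`: 11%
compound 2 `CCNCc1ccc(Cl)c(-c2ccccc2OC)c1`: 71%
compound 3 `CCCCNCc1ccc(Cl)c(-c2ccccc2OC)c1`: "not active" (no number reported)

In a functional assay on HEK293 cells for agonist activity at 5-hydroxytryptamine receptor 7 (Homo sapiens), read by cAMP accumulation, with a stated time of 30 min (a higher number here means a larger maximal response, a lower number a smaller maximal response), compound 1 gives 11%, the lowest of the two numbers recorded, while compound 3 carries no number at all. The shared core stays untouched across the set; only the group on the saturated chain carbon bound to an aromatic carbon changes. Compound 4 `CCCNCc1ccc(Cl)c(-c2ccccc2OC)c1` differs from compound 1 as follows: propylamino in place of dimethylamino on a saturated chain carbon bound to an aromatic carbon. Among the measured compounds shown here, the one measured step that bears on this is a number 60 percentage points higher from compound 1 to compound 2 (beyond the scatter), a large rise when a single ethyl chain on the nitrogen replaces the two methyls. Compound 4 carries a chain longer than the ethylamino of compound 2 yet shorter than the chain of compound 3, which gave "not active" (no number reported). A rise from compound 1 is therefore expected, but not the full rise seen for compound 2, and a report of no activity, as for compound 3, cannot be excluded. The estimate for compound 4 is 40%, within 10% to 75%. The expected step is a number 29 percentage points higher from compound 1 to compound 4 (beyond the scatter).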

Compound 4, largest response reached (Emax), in percent of the reference or control that the assay uses: 68%
Beside the measured number, compound 4's estimate is 28 percentage points below it, within the range that was stated.
By their numbers in this assay, from the lowest: compound 1; then compounds 4 and 2 (each within the scatter of the next).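

In this assay, the large gain is not tied to the ethylamino group alone: propylamino in place of dimethylamino on a saturated chain carbon bound to an aromatic carbon gives a number 57 percentage points higher from compound 1 to compound 4 (beyond the scatter) at this position. Methyl in place of hydrogen on the ethylamino chain gives a number 3 percentage points lower from compound 2 to compound 4 (within the scatter), so these two chains cannot be told apart in this read-out. A simple rule that any single chain on the nitrogen keeps the response fails, since compound 3 is reported as "not active" (no number reported) in this same test.

No measurement here explains why these chains differ. Going by these compounds, it also remains open how a branched chain such as isopropylamino, a methylamino group or a plain primary amine would behave at this position.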